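Aryl Sulfonamide Leucine Amides and a Pyrimidine Swap

This account rests on a few compounds, and the source may have more. Where it says the series, first, only, none or still open, it means among the compounds named here.

The measured compounds, in an assay on isolated protein for inhibition of leucine--tRNA ligase, cytoplasmic (Homo sapiens); a lower number here means a stronger inhibitor, a higher number a weaker inhibitor:
Compound 1 `CC(C)C[C@H](N)C(=O)NS(=O)(=O)c1cccc(-c2cccc(N)n2)c1` gives 850 nM.
Compound 2 `CC(C)C[C@H](N)C(=O)NS(=O)(=O)c1ccccc1` gives 1100 nM.
Compound 3 `CC(C)C[C@H](N)C(=O)NS(=O)(=O)c1ccc2ccccc2c1` gives 220 nM.

Among these three, compound 1 stands second highest; compound 2 is nearest to it in this assay, and compound 3 is furthest, with a lower number that lies beyond the scatter.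

The new compound 4 `Cc1cc(-c2cccc(S(=O)(=O)NC(=O)[C@@H](N)CC(C)C)c2)nc(N)n1` differs from compound 1 in one place: 2-amino-6-methylpyrimidin-4-yl in place of 6-aminopyridin-2-yl on an aromatic carbon. Going by the values given here, only one measured step bears on this position, a 1.3-fold higher number from compound 1 to compound 2 (0.11 log units; within the scatter), which shows that removing the 6-aminopyridin-2-yl group altogether changed the number by no more than the scatter. Compound 3 carries a different core and gives no direct guidance for this exchange. Among the compounds with values here, since the group at this position made little difference in the one step available, the exchange of one aromatic amine-bearing ring for another is expected to move the number by little, perhaps a small step toward a lower number, and the expected step is a 1.4-fold lower number from compound 1 to compound 4 (0.15 log units; within the scatter). Compound 4 is therefore estimated at 600 nM, within a range from 250 nM to 1500 nM.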

Compound 4, half-maximal inhibitory concentration: 160 nM
Compound 4: middle estimate off by 3.8-fold (0.57 log units), on the high side; the measured number lies below the stated range.
By their numbers in this assay, from the lowest: compounds 4 and 3 (each within the scatter of the next); then compounds 1 and 2 (each within the scatter of the next).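

In this assay, the place on an aromatic carbon meta to a large group proves sensitive to what it carries: a 6.9-fold lower number from compound 2 to compound 4 (0.84 log units; beyond the scatter) is seen when 2-amino-6-methylpyrimidin-4-yl replaces hydrogen, while 6-aminopyridin-2-yl gave only a 1.3-fold higher number from compound 1 to compound 2 (0.11 log units; within the scatter) as a change from that group to hydrogen. The two aromatic amine-bearing rings are therefore not interchangeable, as a 5.3-fold lower number from compound 1 to compound 4 (0.73 log units; beyond the scatter) shows directly in a single exchange. No measurement given here accounts for this difference.

The exchange adds a second ring hetero atom and a methyl group together, so the compounds shown do not say which of the two carries the step. As far as these compounds go, a 2-aminopyrimidin-4-yl group without the methyl would separate them, and it also remains open whether the ring amine could give way to a hydroxyl or a methoxy group.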